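The compounds below may be only part of what the source reports. "The series", "measured", "known", "first", "only" and "open" are said of these compounds alone.

Compound 1 `Oc1ccc(-c2nc3c(NC4CCCC4)cccn3c2-c2ccnc(NC3CCCC3)n2)cc1` and compound 2 `COc1cccc(-c2nc3c(NC4CCCC4)cccn3c2-c2ccnc(NC3CCCC3)n2)c1` share one core and differ only in the aryl group attached to it. In an ADME assay on Vero cells (Chlorocebus sabaeus) for cytotoxicity (a higher number here means that more compound is tolerated, a lower number that less compound is tolerated), compound 1 gives > 40000 nM, which is a limit of the assay rather than a number. Compound 2 gives > 40000 nM in this assay, again only a limit. The step that the two limits leave unreadable from compound 1 to compound 2 therefore has no readable size, as the limit of > 40000 nM in this assay, at which 2 of the 2 values shown sit, shows. Compound 3 `N#Cc1cccc(-c2nc3c(NC4CCCC4)cccn3c2-c2ccnc(NC3CCCC3)n2)c1` carries one further change: cyano in place of methoxy on an aromatic carbon. No measured step sizes this change. Compound 3 is expected to give 50000 nM, within a range from 25000 nM to 120000 nM. The expected step that the limit leaves unreadable from compound 2 to compound 3 is estimated to be none beyond the scatter.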

Compound 3, half-maximal cytotoxic concentration: > 40000 nM
Compound 3: only a limit was reported; the forecaster's own chance of this, stated with the estimate: 80%; the middle value lies beyond the limit too.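

The steps among compound 1, compound 2 and compound 3 cannot be read, as all three give only a limit: the limit of > 40000 nM in this assay, at which 3 of the 3 values shown sit. The compounds shown leave open whether the 4-hydroxyphenyl, 3-methoxyphenyl and 3-cyanophenyl groups differ at all in this assay.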